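From Oxan-2-yl to Oxolan-2-yl: Compound 3

The source may report more compounds than this note shows. Statements on the series, on what has been measured and on what is new or still open speak of the compounds shown alone.

Compound 1 `COc1ccc(CNc2ncnc3c2ncn3C2CCCCO2)c(OC)c1`: > 25000 nM
Compound 2 `COc1ccc(CNc2ncnc3c2ncn3C2CCCCO2)c(OC)c1OC`: > 37500 nM

Both compounds were tested in an ADME assay on MCF7 cells (Homo sapiens) for cytotoxicity, with a stated time of 72 h; on this read-out higher numbers stand for weaker inhibition and lower numbers for stronger inhibition. In this assay compound 1 gives > 25000 nM, which is a limit and not a number. Compound 2 gives > 37500 nM, which is also a limit. Compound 1 therefore has no exact value as a starting point, and its position is the limit of > 25000 nM in this assay, at which 1 of the 2 values shown sits. The other value available is the limit of > 37500 nM in this assay, at which 1 of the 2 values shown sits.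

Compound 3 `COc1ccc(CNc2ncnc3c2ncn3C2CCCO2)c(OC)c1` differs from compound 1 in one place: oxolan-2-yl in place of oxan-2-yl on an aromatic nitrogen. Oxolan-2-yl stands in place of oxan-2-yl on an aromatic nitrogen.

For the measured compounds named here, the only measured step is a step that the two limits leave unreadable from compound 1 to compound 2. That step puts methoxy in place of hydrogen on an aromatic carbon, which is a different change from the one made here, and its size cannot be read. It offers no guide to size or direction, so no step beyond the scatter is expected. The expectation rests on compound 1, whose value of > 25000 nM is a limit. The expected change is a step that the limit leaves unreadable from compound 1 to compound 3. In this assay the estimate for compound 3 is 30000 nM, with an expected range from 12000 nM to 70000 nM.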

Compound 3, half-maximal inhibitory concentration: > 100000 nM
Compound 3: only a limit was reported (the forecaster's own chance of this, stated with the estimate: 75%); middle value at least 3.3-fold (0.52 log units) from the limit.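

The values of compound 1 and compound 3 in this assay are both limits and not numbers, and the step between these two compounds cannot be read. The compounds shown leave open what exact value any of them has in this assay, and whether oxolan-2-yl in place of oxan-2-yl on an aromatic nitrogen changes that value at all.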